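The source may hold more compounds than are shown below. What is called first, only, known or untested is meant among the compounds shown, and "the series" means these compounds.

The measured compounds:
Compound 1 `CN(C)c1ccc(/C=C2\CCC/C(=C\c3ccccc3[N+](=O)[O-])C2=O)cc1` gives 168000 nM in a functional assay on CCRF-CEM cells (Homo sapiens) for cytotoxicity, with a stated time of 72 h; a higher number here means a weaker inhibitor, a lower number a stronger inhibitor.
Compound 2 `O=C1/C(=C/c2ccc(Cl)cc2)CCC/C1=C\c1ccccc1[N+](=O)[O-]` gives 1750 nM in this assay.
Compound 3 `O=C1/C(=C/c2ccc(Cl)cc2)CCC/C1=C\c1cccc([N+](=O)[O-])c1` gives 1750 nM in this assay.

Compound 2 and compound 3 are built from the same atoms joined differently; the difference between the two cores is not broken down here. In this assay compound 3 is level with compound 2 as far as the digits go, a gap that lies within the usual scatter, and the two together stand as the lowest numbers of the three. Going by the values given here, the one counted change among the measured compounds is dimethylamino in place of chloro on an aromatic carbon, which brought a 96-fold higher number from compound 2 to compound 1 (1.98 log units; beyond the scatter).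

Compound 4 `CN(C)c1ccc(/C=C2\CCC/C(=C\c3cccc([N+](=O)[O-])c3)C2=O)cc1` stands to compound 3 as compound 1 stands to compound 2: the change is dimethylamino in place of chloro on an aromatic carbon, made at the same place in both pairs, so it is the same change. It is expected to move the number by about as much as the earlier one did, because that earlier step was a 96-fold higher number from compound 2 to compound 1 (1.98 log units; beyond the scatter). The step expected is a 91-fold higher number from compound 3 to compound 4 (1.96 log units; beyond the scatter). Compound 4 is therefore expected to give about 160000 nM, with an estimated range from 50000 nM to 500000 nM.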

Compound 4, half-maximal inhibitory concentration: 11700 nM
Beside the measured number, compound 4's estimate is 14-fold (1.14 log units) above it; measured number outside the range, below it.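

In this assay dimethylamino in place of chloro gives a higher number on both cores, with a 6.7-fold higher number from compound 3 to compound 4 (0.83 log units; beyond the scatter) on the core bearing 3-nitrophenyl, so the direction of the step carries over but its size does not: the same change on two cores in this assay, a 96-fold higher number (1.98 log units; beyond the scatter) from compound 2 to compound 1 and a 6.7-fold higher number (0.83 log units; beyond the scatter) from compound 3 to compound 4, 14-fold (1.16 log units) apart, beyond the scatter of two such steps. With dimethylamino in place, 3-nitrophenyl in place of 2-nitrophenyl brings a 14-fold lower number from compound 1 to compound 4 (1.16 log units; beyond the scatter) in the same assay, whereas compound 2 and compound 3, both carrying 4-chlorophenyl, lie within the scatter of each other. These two pairs show that the size of this step depends on the core in this series, but they do not show why, and they cannot tell which of the two sizes a further core would follow.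

The compounds shown leave open how an amine without the methyl groups or a methoxy group in the same place would behave on each core. They also leave open whether the same dependence on the core would hold with a nitrile or a carboxylic acid in place of the nitro group.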